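This account rests on a few compounds, and the source may have more. Where it says the series, first, only, none or still open, it means among the compounds named here.

- Compound 1 `Cc1nnsc1CO/N=C/c1c(C)nn(C)c1Oc1ccccc1Cl` gives > 50000 nM (a limit of the assay)
- Compound 2 `Cc1cccc(Oc2c(/C=N/OCc3snnc3C)c(C)nn2C)c1` gives 12800 nM (a measured number)

Within the data shown here, in a functional assay on SGC-7901 cells (Homo sapiens) for inhibition, read by MTT assay, with a stated time of 48 h (a lower number here means a stronger inhibitor, a higher number a weaker inhibitor), compound 2 at 12800 nM holds the only actual number so far. Compound 3 `Cc1ccc(Oc2c(/C=N/OCc3snnc3C)c(C)nn2C)cc1` differs from it in one place: 4-methylphenyl in place of 3-methylphenyl on an oxygen on an aromatic ring (4-methylphenyl in place of 3-methylphenyl). Among the measured compounds shown here, the one measured step at this place (which is an at least 3.9-fold lower number from compound 1 to compound 2 (0.59 log units; beyond the scatter)) shows that this group can matter, but it was a different swap and starts from a limit. No step beyond the scatter is expected here. The estimated change is a 1.1-fold higher number from compound 2 to compound 3 (0.04 log units; within the scatter) (a small one). Compound 3 is expected near 14000 nM (range 6000 nM to 35000 nM) in this assay when measured.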

Compound 3, half-maximal inhibitory concentration: 12800 nM
Estimate against measurement, compound 3: 1.1-fold (0.04 log units) above, and the stated range covers the measured number.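

In this assay, 4-methylphenyl in place of 3-methylphenyl gives no change at the digits printed from compound 2 to compound 3 (within the scatter), so this assay does not tell these two methylphenyl groups apart. Against 2-chlorophenyl, 4-methylphenyl gives an at least 3.9-fold lower number from compound 1 to compound 3 (0.59 log units; beyond the scatter), so the second methylphenyl group also reads lower than the chlorinated one. The true size of that step stays unknown, since compound 1 stands at a limit of the assay: the limit of > 50000 nM in this assay, at which 1 of the 3 values shown sits.

Still open, as far as these compounds go, is how 2-methylphenyl or 4-chlorophenyl would read, which would help separate the effect of swapping chlorine for methyl from that of where the group sits. Also open, from the compounds shown here alone, is whether an amine on this ring would lower the number further.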